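A few compounds are considered here, and "the series" means these few. Any claim that something is new, unique, unknown or untested is made for them only; others in the source may bear on it.

Of the compounds shown here, two have so far been measured in an ADME assay on MT4 cells (Homo sapiens) for cytotoxicity, read by MTT assay; on this read-out lower numbers stand for higher toxicity in this test and higher numbers for lower toxicity in this test. Compound 1 `NC(=S)N1Nc2onc(-c3ccccc3)c2C1c1ccc(Cl)cc1` gives 340 nM in this assay. Compound 2 `Cc1nc(N2Nc3onc(-c4ccccc4)c3C2c2ccc(Cl)cc2)sc1/N=N/c1ccccc1` gives 260 nM in this assay. Compound 2 thus holds the lower of the two numbers, but its gap to compound 1 lies within the scatter of repeated measurements, so the two compounds cannot be told apart on this read-out. Compound 3 `Cc1ccc(/N=N/c2sc(N3Nc4onc(-c5ccccc5)c4C3c3ccc(Cl)cc3)nc2C)cc1` has not yet been measured. It differs from compound 2 in a single place: methyl in place of hydrogen on an aromatic carbon. Among the compounds with values here, no measured pair shows what this kind of change does here, and no step beyond the scatter is expected from it in this assay, in either direction. Compound 3 is therefore expected to give about 260 nM, within a range from 110 nM to 620 nM. The estimated step is no change at the digits printed from compound 2 to compound 3 (within the scatter), which is small.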

Compound 3, half-maximal cytotoxic concentration: 450 nM
Compound 3: the middle estimate sits 1.7-fold (0.24 log units) below what was measured, and the stated range covers the measured number.
By their numbers in this assay, from the lowest: compounds 2, 1 and 3 (each within the scatter of the next).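

Within the data shown here, this is the first pair of measured compounds that differ in one place, so it gives the first direct reading of a change on this ring. In this assay, among these compounds, going from phenyl to 4-methylphenyl gives a 1.7-fold higher number from compound 2 to compound 3 (0.24 log units; within the scatter) and so leaves the two compounds indistinguishable on this read-out: a methyl on this aromatic carbon, para to a large group, produces no step that can be separated from the ordinary spread of repeated measurements. No other information is available that would help interpret this result.

The compounds shown leave open whether a different group at this position, such as an amine, a carboxylic acid or a longer chain, would produce a step beyond the scatter. They also leave open whether a methyl on another carbon of this ring would behave in the same way.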